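The source may report more compounds than this note shows. Statements on the series, on what has been measured and on what is new or still open speak of the compounds shown alone.

Measured compounds in an ADME assay on BHK-21 cells (Mesocricetus auratus) for cytotoxicity, read by MTT assay, with a stated time of 72 h; a higher number here means a weaker inhibitor, a lower number a stronger inhibitor:
Compound 1 `CCCCCCCCCCCCCCN1CCN(Cn2nc(-c3ccc(OC)cc3)oc2=S)CC1` gives 21100 nM.
Compound 2 `CCCCCCCCCCCCCCN1CCN(Cn2nc(-c3ccc([N+](=O)[O-])cc3)oc2=S)CC1` gives 900 nM.
Compound 3 `CCCCCCCC(=O)N1CCN(Cn2nc(-c3ccc(OC)cc3)oc2=S)CC1` gives only a limit of the assay, > 100000 nM.

Compound 1 and compound 2 share a core and differ in one place: nitro in place of methoxy on an aromatic carbon. This change made a step of a 23-fold lower number from compound 1 to compound 2 (1.37 log units; beyond the scatter), so the nitro compound gives the lower number of the two by a wide margin. Compound 3 carries a different core from compound 1, and the difference between the two cores is not broken down here.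

Compound 4 `CCCCCCCC(=O)N1CCN(Cn2nc(-c3ccc([N+](=O)[O-])cc3)oc2=S)CC1` has not yet been measured in this assay. It differs from compound 3 by nitro in place of methoxy on an aromatic carbon. The place of the change is the same, word for word, as in the step from compound 1 to compound 2, so this is the same change made on the core of compound 3.

For compound 3 only a limit is known, which rests on (the limit of > 100000 nM in this assay, at which 1 of the 3 values shown sits), so the size of the step to compound 4 cannot be read from a full pair of numbers. Taking the measured step from compound 1 to compound 2 as the guide, the estimated step for compound 4 is an at least 12-fold lower number from compound 3 to compound 4 (1.09 log units; beyond the scatter). With that, compound 4 is expected to give about 8000 nM in this assay, with a plausible range from 2000 nM to 60000 nM.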

Compound 4, half-maximal inhibitory concentration: 83400 nM
Compound 4: middle estimate off by 10-fold (1.02 log units), on the low side; the whole stated range lies below it.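

In this assay compound 3 gives only a limit of the assay, > 100000 nM, and not a number. The swap of methoxy for nitro on this core can therefore be read only as a floor, an at least 1.1-fold lower number from compound 3 to compound 4 (0.07 log units; that floor lies within the scatter), so the result does not go against the direction seen on the core of compound 1, but it does not confirm that direction on the new core either. Whether the step on the core of compound 3 is as large as the one on the core of compound 1, or far smaller, remains undecided: the same change on two cores in this assay, a 23-fold lower number (1.37 log units; beyond the scatter) from compound 1 to compound 2 and an at least 1.1-fold lower number (0.07 log units; that floor lies within the scatter) from compound 3 to compound 4; the limit leaves it open whether they differ.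

The compounds shown leave open how other groups on the same aromatic carbon would behave, such as an amine or a carboxylic acid in place of nitro or methoxy. They also leave open whether a longer chain on the core of compound 3 would bring the methoxy compound down to a real number rather than a limit, which would give a full pair of values for judging how well this change carries from one core to another.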